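The source may hold more compounds than are shown below. What is called first, only, known or untested is meant among the compounds shown, and "the series" means these compounds.

Working notes on the series.

Compound 1 `C=CC[C@H]1C[C@]2([C@H](C)Cc3ccc(OC)c(OC)c3)OCOC2=CC1=O` carries two methoxy groups on its aromatic ring; compound 2 `C=CC[C@H]1C[C@]2([C@H](C)Cc3ccc(OC)cc3)OCOC2=CC1=O` has one. In a functional assay on M14 cells (Homo sapiens) for antiproliferative activity, with a stated time of 72 h (a higher number here means a weaker inhibitor, a lower number a stronger inhibitor), compound 1 gives 300 nM, and compound 2 gives 81 nM. The change hydrogen in place of methoxy on an aromatic carbon made the step of a 3.7-fold lower number from compound 1 to compound 2 (0.57 log units; beyond the scatter).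

Compound 3 `C=CC[C@H]1C[C@]2([C@@H](C)Cc3cccc(OC)c3)OCOC2=CC1=O` is the weakest of the three measured: in this assay compound 3 gives 8800 nM. The difference between the cores of compound 3 and compound 1 is not broken down here.

Compound 4 `C=CC[C@H]1C[C@]2([C@@H](C)Cc3ccccc3)OCOC2=CC1=O` is not yet measured. It differs from compound 3 by hydrogen in place of methoxy on an aromatic carbon, the same kind of change as between compound 1 and compound 2, though the place differs: in compound 1 the leaving methoxy sits ortho to a methoxy group, whereas in compound 3 it does not. For the measured compounds named here, only one earlier instance exists, so the step is expected to be smaller and less certain: a 2.5-fold lower number from compound 3 to compound 4 (0.40 log units; beyond the scatter). For compound 4 in this assay the estimate is 3500 nM, between 1000 nM and 12000 nM.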

Compound 4, half-maximal inhibitory concentration: 5100 nM
Estimate against measurement, compound 4: 1.5-fold (0.16 log units) below, within the range that was stated.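

In this assay, the change from 3-methoxyphenyl to phenyl gives a 1.7-fold lower number from compound 3 to compound 4 (0.24 log units; within the scatter) and so does not separate compound 3 from compound 4. Two pairs on two cores, with the methoxy leaving a different place on the ring in each, fit the change carrying over but do not establish it, and only the earlier step lies beyond the scatter, so no dependable gain in this assay follows from the change. The two instances themselves do not separate: the same change on two cores in this assay, a 3.7-fold lower number (0.57 log units; beyond the scatter) from compound 1 to compound 2 and a 1.7-fold lower number (0.24 log units; within the scatter) from compound 3 to compound 4, 2.1-fold (0.33 log units) apart, within the scatter of two such steps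

The compounds shown leave open whether a hydroxyl or an amine on the aromatic ring in place of the methoxy would give a similar step. Also open, on these data alone, is whether the same change would hold with a longer chain in place of the allyl group.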